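The compounds below may be only part of what the source reports. "The series", "measured", "known", "first", "only" and "open" are said of these compounds alone.

Of the compounds shown here, three built on one shared core have been tested in a functional assay for inhibition of metabotropic glutamate receptor 5 (Homo sapiens), read by FLIPR and calcium flux; on this read-out lower numbers stand for stronger inhibition and higher numbers for weaker inhibition. Compound 1 `Cc1cccc(C#CCCc2cccc(Cl)c2)n1` gives 5 nM, compound 3 `Cc1cccc(C#CCSc2cccc(Cl)c2)n1` gives 43 nM, and compound 2 `Cc1cccc(C#CCNc2cccc(Cl)c2)n1` gives 174 nM, the highest of the three numbers: compound 3 sits a step below it and compound 1 far below it, both gaps beyond the scatter. Compound 4 `Cc1cccc(C#CCNc2ccccc2)n1` differs from compound 2 in one place: hydrogen in place of chloro on an aromatic carbon, on an aromatic carbon of a six-membered aromatic ring of carbon only, meta to a large group. Among the compounds with values here, no measured pair shows this same change, so its size is open. A modest loss of inhibition is expected, a step of a 2.9-fold higher number from compound 2 to compound 4 (0.46 log units; beyond the scatter). The estimated value for compound 4 in this assay is 500 nM, within a range of 150 nM to 2000 nM.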

Compound 4, half-maximal inhibitory concentration: 223 nM
Compound 4: middle estimate off by 2.2-fold (0.35 log units), on the high side; the measured number falls inside the stated range.
By their numbers in this assay, from the lowest: compound 1; then compound 3; then compounds 2 and 4 (each within the scatter of the next).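

In this assay, hydrogen in place of chloro on this aromatic carbon gives a small step (a 1.3-fold higher number from compound 2 to compound 4 (0.11 log units; within the scatter)), so the two compounds cannot be told apart. The chloro is therefore not needed to keep this level of inhibition, at least with the rest of compound 2 unchanged. No supporting data bear on why this change matters so little.

As far as these compounds go, whether the same swap would be as quiet on compound 1 or compound 3 remains open. So does whether a different group on this carbon, such as fluoro, methoxy or trifluoromethyl, would shift the number.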